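This account rests on a few compounds, and the source may have more. Where it says the series, first, only, none or still open, it means among the compounds named here.

Compound 1, `O=C(NCc1ccc(C(=O)N2CCCCc3ccccc32)c(F)c1)Nc1c(F)cccc1F`: 180 nM
Compound 2, `CCc1cc(C(=O)N2CCCCc3ccccc32)ccc1CNC(=O)Nc1c(F)cccc1F`: 10 nM
Compound 3, `Cc1cc(C(=O)N2CCCCc3ccccc32)ccc1CNC(=O)NCC(=O)OC(C)C`: 140 nM

All three were tested in a functional assay on HEK293 cells for agonist activity at Vasopressin V2 receptor (Homo sapiens), read by a luciferase reporter and cAMP accumulation; a lower number here means that less compound is needed, a higher number that more compound is needed for the effect. Among the three numbers, compound 3 stands second highest. Its nearest neighbour is compound 1, and the two values lie within the usual scatter of each other, so nothing separates them. Its furthest neighbour is compound 2, whose number is clearly lower, a gap that goes beyond the scatter.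

Compound 4, `Cc1cc(C(=O)N2CCCCc3ccccc32)ccc1CNC(=O)N1CCC[C@H]1C(=O)OC(C)C`, has not yet been measured. It differs from compound 3 in one place: 2-(isopropoxycarbonyl)pyrrolidin-1-yl in place of ((isopropoxycarbonyl)methyl)amino on a carbonyl carbon. The urea nitrogen of compound 3, which carries a hydrogen-bond donor, becomes part of a five-membered ring in compound 4, and the donor count drops to zero while the isopropyl ester is kept. Going by the values given here, no pair of measured compounds shows a step of this kind, so the direction has to be guessed from the general picture, in which the two ester-bearing ureas, compounds 3 and 1, already sit at the higher end. A small rise in the number is expected for compound 4, though one that may not clear the scatter, giving an estimated step of a 1.8-fold higher number from compound 3 to compound 4 (0.25 log units; within the scatter). Compound 4 is therefore estimated at 250 nM, with a range from 60 nM to 1000 nM.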

Compound 4, half-maximal effective concentration: 950 nM
Estimate against measurement, compound 4: 3.8-fold (0.58 log units) below, and the stated range covers the measured number.
By their numbers in this assay, from the lowest: compound 2; then compounds 3 and 1 (each within the scatter of the next); then compound 4.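

Replacing ((isopropoxycarbonyl)methyl)amino with 2-(isopropoxycarbonyl)pyrrolidin-1-yl on this carbonyl carbon in this assay gives a 6.8-fold higher number from compound 3 to compound 4 (0.83 log units; beyond the scatter), the first step measured at this position. The isopropyl ester is present on both sides of the step, so its presence alone does not fix the number: what else stands on the carbonyl carbon matters, and here the change means that more compound is needed for the effect. No measurement available here bears on why the number moves, so the step stands as an observation only.

This one step changes several things together, since the amide hydrogen leaves, a five-membered ring enters and a defined stereocentre appears, and the compounds shown cannot say which of these goes with the rise. A plain methyl group on the urea nitrogen with no ring, the opposite configuration at the stereocentre, a six-membered piperidine ring or a free carboxylic acid in place of the isopropyl ester would each test a separate part of the question.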